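Chloro to methoxy: compound 4 in a narrow series

The compounds below may be only part of what the source reports. "The series", "measured", "known", "first", "only" and "open" are said of these compounds alone.

In a functional assay on MCF7 cells (Homo sapiens) for antiproliferative activity, read by MTT assay, with a stated time of 48 h (a higher number here means a weaker inhibitor, a lower number a stronger inhibitor), compound 1 (`COc1ccc(-c2nnc(NC(=O)/C=C/c3ccc(F)cc3)s2)cc1`) gives 0.85 ug/mL and compound 2 (`COc1ccc(-c2nnc(NC(=O)/C=C/c3ccccc3)s2)cc1`) gives 0.78 ug/mL. Compound 3 (`COc1ccc(/C=C/C(=O)Nc2nnc(-c3ccc(Cl)cc3)s2)cc1`) gives 0.91 ug/mL, within the scatter of both. Compound 4 (`COc1ccc(/C=C/C(=O)Nc2nnc(-c3ccc(OC)cc3)s2)cc1`) differs from compound 3 in one place: methoxy in place of chloro on an aromatic carbon. This is methoxy in place of chloro on an aromatic carbon. Going by the values given here, the only measured step, a 1.1-fold lower number from compound 1 to compound 2 (0.04 log units; within the scatter), is a different exchange, hydrogen in place of fluoro, and it offers only indirect guidance. Among the compounds with values here, no measured step exchanges chloro for methoxy, so the direction stays open and no shift beyond the scatter is expected in this assay. The estimate amounts to a 1.1-fold lower number from compound 3 to compound 4 (0.03 log units; within the scatter), an expected step within the scatter. Compound 4 is expected at 0.85 ug/mL, with an estimated range of 0.4 ug/mL to 1.9 ug/mL.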

Compound 4, half-maximal inhibitory concentration: 0.28 ug/mL
For compound 4 the middle estimate is 3.0-fold (0.48 log units) above the measured one; the measured number lies below the stated range.
By their numbers in this assay, from the lowest: compound 4; then compounds 2, 1 and 3 (each within the scatter of the next).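

Methoxy is the first change here to carry the number beyond the scatter in this assay: in place of chloro it gives a clear step (a 3.3-fold lower number from compound 3 to compound 4 (0.51 log units; beyond the scatter)). The same group on the other aromatic ring, in place of hydrogen (a 2.8-fold lower number from compound 2 to compound 4 (0.44 log units; beyond the scatter)) or fluoro (a 3.0-fold lower number from compound 1 to compound 4 (0.48 log units; beyond the scatter)), gives steps of similar size. Compound 4, with methoxy on both rings, thus stands apart from all three earlier compounds. From the compounds shown here alone, whether an amine or a hydroxyl at this place would do the same stays open. Nothing shown here explains the step.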